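From 3-hydroxyphenyl to 4-chlorophenyl on the shared core

This account rests on a few compounds, and the source may have more. Where it says the series, first, only, none or still open, it means among the compounds named here.

In a functional assay on A549 cells (Homo sapiens) for inhibition, read by MTT assay, with a stated time of 24 h (on this read-out higher numbers stand for weaker inhibition and lower numbers for stronger inhibition), compound 1 (`CC1(C)[C@H]2CC[C@]1(C)N(Cc1cn(-c3ccccc3C#N)nn1)C(=O)C2`) gives 100 nM, compound 2 (`CC1(C)[C@H]2CC[C@]1(C)N(Cc1cn(-c3ccccc3F)nn1)C(=O)C2`) gives 240 nM and compound 3 (`CC1(C)[C@H]2CC[C@]1(C)N(Cc1cn(-c3cccc(O)c3)nn1)C(=O)C2`) gives 180 nM. The last value lies within the scatter of both others, with a 1.8-fold higher number from compound 1 to compound 3 (0.26 log units; within the scatter) and a 1.3-fold lower number from compound 2 to compound 3 (0.12 log units; within the scatter). Compound 4 (`CC1(C)[C@H]2CC[C@]1(C)N(Cc1cn(-c3ccc(Cl)cc3)nn1)C(=O)C2`) carries 4-chlorophenyl in place of 3-hydroxyphenyl on an aromatic nitrogen. Going by the values given here, the largest measured step, a 2.4-fold higher number from compound 1 to compound 2 (0.38 log units; beyond the scatter), is only modest, and no measured compound carries a chlorine, so the guidance is indirect. No step beyond the scatter is expected in this assay, the expected step being a 1.1-fold higher number from compound 3 to compound 4 (0.05 log units; within the scatter). Compound 4 is estimated at 200 nM, with an expected range from 90 nM to 450 nM.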

Compound 4, half-maximal inhibitory concentration: 70 nM
Compound 4: middle estimate off by 2.9-fold (0.46 log units), on the high side, outside the stated range (below it).
By their numbers in this assay, from the lowest: compounds 4, 1, 3 and 2 (each within the scatter of the next, the first and the last beyond it).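

In this assay the 4-chlorophenyl group sets compound 4 apart from two earlier compounds, with a 2.6-fold lower number from compound 3 to compound 4 (0.41 log units; beyond the scatter) and a 3.4-fold lower number from compound 2 to compound 4 (0.54 log units; beyond the scatter) as the steps. Against the 2-cyanophenyl group there is no separation, with a 1.4-fold lower number from compound 1 to compound 4 (0.15 log units; within the scatter) as the step, so compound 1 and compound 4 share the low end of the series. Nothing available explains these steps.

The compounds shown do not separate the effect of chlorine from the effect of its place on the phenyl ring. On these data alone, how an amine or a carboxylic acid on that ring would read also remains open.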